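The source may hold more compounds than are shown below. What is called first, only, known or untested is meant among the compounds shown, and "the series" means these compounds.

Within the data shown here, in a functional assay on HCT-116 cells (Homo sapiens) for cytotoxicity, read by MTT assay, with a stated time of 72 h (a higher number here means a weaker inhibitor, a lower number a stronger inhibitor), compound 1 (`O=C1c2c[n+]([O-])c3ccccc3c2C(=O)c2c1c1ccccc1n2Cc1cn([C@H]2O[C@H](CO)[C@@H](O)[C@H]2O)nn1`) gives 710 nM and compound 2 (`O=C1c2c[n+]([O-])c3ccccc3c2C(=O)c2c1c1ccccc1n2Cc1cn(CC(O)CO)nn1`) gives 250 nM, the lower of the two numbers so far. Compound 3 (`CC1(C)O[C@@H](CO)[C@H](Cn2cc(Cn3c4c(c5ccccc53)C(=O)c3c[n+]([O-])c5ccccc5c3C4=O)nn2)O1`) keeps the core of compound 2 and alters its side chain on a saturated chain carbon bound to an aromatic nitrogen: 5-(hydroxymethyl)-2,2-dimethyl-1,3-dioxolan-4-yl in place of 1,2-dihydroxyethyl on a saturated chain carbon bound to an aromatic nitrogen. Among the measured compounds shown here, only one measured step bears on this. Replacing 3,4-dihydroxy-5-(hydroxymethyl)oxolan-2-yl with 2,3-dihydroxypropyl on an aromatic nitrogen gave a 2.8-fold lower number from compound 1 to compound 2 (0.45 log units; beyond the scatter), a modest step beyond the scatter. That change is not the same as the one now at issue, so it offers only a loose guide, but compound 3 again carries a ring in this side chain, as compound 1 does. A modest rise is therefore expected, estimated as a 2.0-fold higher number from compound 2 to compound 3 (0.30 log units; within the scatter). For compound 3 the expected value is 500 nM, with an estimated range from 170 nM to 1400 nM.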

Compound 3, half-maximal inhibitory concentration: 130 nM
For compound 3 the middle estimate is 3.8-fold (0.59 log units) above the measured one, outside the stated range (below it).
By their numbers in this assay, from the lowest: compounds 3 and 2 (each within the scatter of the next); then compound 1.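

On a saturated chain carbon bound to an aromatic nitrogen, the change to 5-(hydroxymethyl)-2,2-dimethyl-1,3-dioxolan-4-yl gives a 1.9-fold lower number from compound 2 to compound 3 (0.28 log units; within the scatter) in this assay and so stays within the scatter, even with a five-membered non-aromatic ring and 2 defined stereocentres replacing the open 1,2-dihydroxyethyl. A ring in the side chain therefore does not by itself go with a higher number, for the two ring-bearing side chains stand apart in this assay with a 5.5-fold lower number from compound 1 to compound 3 (0.74 log units; beyond the scatter) between them on the shared core. Nothing at hand accounts for either step. On these data alone, it remains open whether an amine or a carboxylic acid on this side chain would keep the number in this range. Among these compounds, the part played by the 2 defined stereocentres also remains open, since no compound here carries the opposite arrangement.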